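A few compounds are considered here, and "the series" means these few. Any claim that something is new, unique, unknown or untested is made for them only; others in the source may bear on it.

Measured compounds:
compound 1, `N#C/N=C(/NCCCCc1c[nH]cn1)NCCCc1ccccc1`, 5.25
compound 2, `N#C/N=C(\NCCCCCc1c[nH]cn1)NCCSc1ccccc1`, 5.21
compound 3, `CCN/C(=N/C#N)NCCCCCc1c[nH]cn1`, 5.37

All three were tested in an in vitro functional assay on Sf9 cells for antagonist activity at histamine H2 receptor (Homo sapiens); on this read-out lower numbers stand for lower potency and higher numbers for higher potency (the scale is a negative logarithm). Compound 3 sits at the top of the three numbers, but its gap to compound 1 and its gap to compound 2 are both within the scatter of repeated measurements, so the three cannot really be told apart.

Compound 4, `CC(C)N/C(=N/C#N)NCCCCCc1c[nH]cn1`, differs from compound 3 in one place: methyl in place of hydrogen on a saturated chain carbon bound to an amine nitrogen and a saturated chain carbon. The only measured step among these compounds is a different kind of change, the removal of a phenylsulfanyl group, which gave a number 0.16 log units higher from compound 2 to compound 3 (within the scatter), a step within the scatter. Within the data shown here, no measured step adds a methyl to the chain, so there is nothing that directly shows what this change does.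

Among the measured compounds shown here, with no step pointing in either direction, the expected change in this assay is a number 0.03 log units higher from compound 3 to compound 4 (within the scatter), nothing beyond the scatter. Compound 4 is therefore estimated at 5.4, within a range from 4.9 to 5.9.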

Compound 4, negative logarithm of the antagonist equilibrium constant: 5.57
Compound 4: the middle estimate sits 0.17 log units below what was measured; the measured number falls inside the stated range.
By their numbers in this assay, from the lowest: compounds 2, 1, 3 and 4 (each within the scatter of the next, the first and the last beyond it).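

Swapping ethylamino for isopropylamino gives a number 0.20 log units higher from compound 3 to compound 4 (within the scatter) in this assay, the first direct reading of what a methyl does on this saturated chain carbon bound to an amine nitrogen and a saturated chain carbon. The step stays within the scatter, so compound 3 and compound 4 cannot be told apart, and this position accepts the extra methyl without a clear change in the number. No supporting measurement is available to explain this result.

Open, as far as these compounds go, is whether bulkier groups at this place, such as tert-butyl or cyclohexyl, would also leave the number unchanged or would finally move it beyond the scatter. Also open, from the compounds shown here alone, is whether a hydroxyl on this same chain carbon would behave as the methyl does.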